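Compound 4 in rat clearance: working notes

The compounds below may be only part of what the source reports. "The series", "measured", "known", "first", "only" and "open" are said of these compounds alone.

Measured so far in an ADME assay on the whole organism (Rattus norvegicus, strain Sprague-Dawley) for pharmacokinetics, read by LC-MS, at a dose of 0.5 mg/kg by the intravenous route; a lower number here means slower removal, a higher number faster removal of the compound:
- compound 1 `C[C@H](Nc1ncnc(N)c1C#N)c1nc2ccc(F)cc2c(-c2ccccn2)c1-c1ccccn1`: "not determined" (no result reported)
- compound 2 `C[C@H](Nc1ncnc(N)c1C#N)c1nc2ccc(F)cc2c(C(N)=O)c1-c1ccccc1`: 10 mL/min/kg
- compound 3 `C[C@H](Nc1ncnc(N)c1C#N)c1nc2ccc(F)cc2c(C(=O)N(C)C)c1-c1ccccc1`: "not determined" (no result reported)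

Still to be measured:
- compound 4 `CCNC(=O)c1c(-c2ccccn2)c([C@H](C)Nc2ncnc(N)c2C#N)nc2ccc(F)cc12`

Compound 1 has no single number in this assay and compound 3 shares that gap, so compound 2 at 10 mL/min/kg is the only measured clearance in the set. The structural change ethylcarbamoyl in place of pyridin-2-yl on an aromatic carbon puts ethylcarbamoyl in place of pyridin-2-yl on an aromatic carbon, opposite the ring nitrogen. Within the data shown here, the set holds no measured step, and without a number for compound 1 no step can be read from it. In this assay, among the measured compounds shown here, the expectation for compound 4 is therefore a value no further than the scatter from the one available number, with no direction favoured. This expectation rests only on compound 2 at 10 mL/min/kg as an anchor, so the range is kept wide. Compound 4 is estimated at 12 mL/min/kg, with an expected range from 4 mL/min/kg to 35 mL/min/kg.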

Compound 4, clearance: 3.33 mL/min/kg
The estimate for compound 4 lay 3.6-fold (0.56 log units) above the measured number; measured number outside the range, below it.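

Among these compounds, compound 1 has no single number in this assay and so no step to compound 4 can be read. The compounds shown leave open what ethylcarbamoyl in place of pyridin-2-yl does to clearance on the shared core. No measurement at hand bears on the result of compound 4.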